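Chloro for methyl on a quaternary-ammonium chain analogue

The compounds below may be only part of what the source reports. "The series", "measured", "known", "first", "only" and "open" are said of these compounds alone.

Measured compounds:
Compound 1, `Cc1ccc(-n2cc(C(=O)Nc3cc(F)cc(F)c3)c(=O)c3ccc(N(C)C)nc32)cc1OCCCCCCC[N+]12CCN(CC1)CC2`, gives 5.07% in an assay on LX2 cells for inhibition of COL1A1 promoter (Homo sapiens), read by a luciferase reporter, with a stated time of 24 h, tested at 20 uM; on this read-out higher numbers stand for a stronger effect at the one concentration tested and lower numbers for a weaker effect.
Compound 2, `CN(C)c1ccc2c(=O)c(C(=O)Nc3cc(F)cc(F)c3)cn(-c3ccc(Cl)c(OCCCCCCC[N+]45CCN(CC4)CC5)c3)c2n1`, gives 8.08% in this assay.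
Compound 3, `Cc1cc(OCCCCCCC[N+]2(C)CCN(C)CC2)ccc1-n1cc(C(=O)Nc2cc(F)cc(F)c2)c(=O)c2ccc(N(C)C)nc21`, is reported in this assay as "not active" (no number reported), without a number.

The step of a number 3 percentage points higher from compound 1 to compound 2 (within the scatter) rests on the change (chloro in place of methyl on an aromatic carbon). Compound 4, `CN1CC[N+](C)(CCCCCCCOc2ccc(-n3cc(C(=O)Nc4cc(F)cc(F)c4)c(=O)c4ccc(N(C)C)nc43)c(Cl)c2)CC1`, is not yet measured; it stands to compound 3 as compound 2 stands to compound 1, through (chloro in place of methyl on an aromatic carbon). The two changes are the same kind of change, though not the same: the place in the first is para to a large group, in the second meta to a large group. The difference between the two cores, compound 1 against compound 3, is not broken down here. Since compound 3 gives no number, the expectation for compound 4 in this assay rests only on the small size of a number 3 percentage points higher from compound 1 to compound 2 (within the scatter) and on compound 3 being reported as not active. Compound 4 is therefore expected to give about 5%, between 0% and 15%.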

Compound 4, a percentage reported as inhibition, at one concentration (the size of the read-out at that concentration, not a potency): "not active" (no number reported)
For compound 4 the study gives words and no number; no gap can be computed for the estimate.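

Compound 3 and compound 4 are both reported in this assay as not active, without numbers, so no new step can be read between them. No evidence shown bears on this result. The compounds shown leave open whether chloro in place of methyl has any effect on the core of compound 3.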